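Sulfonamide nitrogen substitution in a pyrimidine series

This account rests on a few compounds, and the source may have more. Where it says the series, first, only, none or still open, it means among the compounds named here.

Measured compounds in an assay on Sf9 cells for inhibition of serine/threonine-protein kinase 4 (Homo sapiens), read by luminescence and ADP-Glo, with a stated time of 1 h, in the presence of a further agent that is not named here; on this read-out lower numbers stand for stronger inhibition and higher numbers for weaker inhibition:
Compound 1 `CC1C(=O)N(C)c2cnc(Nc3ccc(S(N)(=O)=O)cc3)nc2N1C` gives 313 nM.
Compound 2 `CNS(=O)(=O)c1ccc(Nc2ncc3c(n2)N(C)C(c2c(F)cccc2F)C(=O)N3C)cc1` gives 318 nM.
Compound 3 `CNS(=O)(=O)c1ccc(Nc2ncc3c(n2)N(C)C(c2ccccc2C)C(=O)N3C)cc1` gives 104 nM.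

Compound 3 has the lowest number of the three in this assay; compound 1 and compound 2 both sit higher, and both gaps lie beyond the scatter. For the measured compounds named here, the only single-point step recorded is a 3.1-fold lower number from compound 2 to compound 3 (0.49 log units; beyond the scatter), and it concerns the aryl group on the saturated ring carbon, not the sulfonamide.

Compound 4 `Cc1ccccc1C1C(=O)N(C)c2cnc(Nc3ccc(S(=O)(=O)NCC4CC4)cc3)nc2N1C` is the next member. It differs from compound 3 by cyclopropyl in place of hydrogen on a saturated chain carbon bound to a sulfonamide nitrogen. Going by the values given here, no measured pair isolates this change. Compound 1 and compound 2 differ at the sulfonamide nitrogen, but also in the aryl group, so their two values, which lie within the scatter of each other, cannot be split into separate contributions. Among the compounds with values here, the step from compound 3 to compound 4 therefore rests on no direct precedent; the working expectation is a small step in this assay, not clearly beyond the scatter, in either direction.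

Compound 4 is estimated at 110 nM, range 40 nM to 300 nM, which means an expected step of a 1.1-fold higher number from compound 3 to compound 4 (0.02 log units; within the scatter).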

Compound 4, half-maximal inhibitory concentration: 60 nM
Beside the measured number, compound 4's estimate is 1.8-fold (0.26 log units) above it; low and high end bracket the measured number.
By their numbers in this assay, from the lowest: compounds 4 and 3 (each within the scatter of the next); then compounds 1 and 2 (each within the scatter of the next).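

In this assay, the sulfonamide nitrogen substituent now has its first single-place reading: methylsulfamoyl gives way to (cyclopropylmethyl)sulfamoyl in a 1.7-fold lower number from compound 3 to compound 4 (0.24 log units; within the scatter), so compound 3 and compound 4 cannot be ordered. The earlier compounds shown here could not show this, since compound 1 and compound 2 differ at this nitrogen and also in the group on the saturated ring carbon. The result shows that a cyclopropyl on the saturated chain carbon bound to the sulfonamide nitrogen, with its 3 added carbon atoms, leaves the number within the scatter of that of the methyl compound, and no measurement at hand accounts for the size of the step.

Open, from the compounds shown here alone, is whether any group at this nitrogen moves the number beyond the scatter, for example a longer chain such as n-butyl, a chain ending in an amine, or one ending in a carboxylic acid. Also open, going by these compounds, are the unsubstituted sulfonamide on the core carrying 2-methylphenyl and the (cyclopropylmethyl)sulfamoyl group paired with 2,6-difluorophenyl, which would show whether the two changes act independently.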